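This account rests on a few compounds, and the source may have more. Where it says the series, first, only, none or still open, it means among the compounds named here.

Measured in a physicochemical assay for lipophilicity; a higher number here means a more lipophilic compound, a lower number a more polar compound:
Compound 1 `C[C@H]1CC[C@@H]2[C@@H](OC(=O)[C@]23CC(c2c(Cl)cccc2Cl)=NO3)[C@]2(C)C(=O)C=C[C@@]12O`: 2.67
Compound 2 `C[C@H]1CC[C@@H]2[C@@H](OC(=O)[C@]23CC(c2ccc(N(C)C)cc2)=NO3)[C@]2(C)C(=O)C=C[C@@]12O`: 1.51
Compound 3 `C[C@H]1CC[C@@H]2[C@@H](OC(=O)[C@]23CC(c2ccc([N+](=O)[O-])cc2)=NO3)[C@]2(C)C(=O)C=C[C@@]12O`: 1.37

The last two of these values sit close together, with a gap of a number 0.14 log units lower from compound 2 to compound 3 (within the scatter). Both lie well away from the first, and compound 3 stands at the low end of the series, with a number 1.30 log units lower from compound 1 to compound 3 (beyond the scatter). The next compound is compound 4 `C[C@H]1CC[C@@H]2[C@@H](OC(=O)[C@]23CC(c2ccccc2F)=NO3)[C@]2(C)C(=O)C=C[C@@]12O`, which carries 2-fluorophenyl in place of 4-nitrophenyl on a carbon with a double bond to nitrogen.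

Going by the values given here, no measured compound carries 2-fluorophenyl, so no measured step matches this change directly. The nearest guide is the step of a number 1.30 log units lower from compound 1 to compound 3 (beyond the scatter), read in reverse, since it also concerns 4-nitrophenyl and a halogen-bearing phenyl. The step of a number 1.16 log units lower from compound 1 to compound 2 (beyond the scatter) is of similar size, while the exchange of nitro and dimethylamino gave only a number 0.14 log units lower from compound 2 to compound 3 (within the scatter). The large steps both start from 2,6-dichlorophenyl, which is not the group entering here, so only a small part of their size is expected to carry over, in the upward direction. The expected step is a number 0.38 log units higher from compound 3 to compound 4 (beyond the scatter). For compound 4 the estimate is 1.75, with an expected range from 1.4 to 2.2.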

Compound 4, partition coefficient: 1.58
For compound 4 the middle estimate is 0.17 log units above the measured one; low and high end bracket the measured number.
By their numbers in this assay, from the lowest: compounds 3, 2 and 4 (each within the scatter of the next); then compound 1.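

In this assay, 2-fluorophenyl in place of 4-nitrophenyl on a carbon with a double bond to nitrogen gives a number 0.21 log units higher from compound 3 to compound 4 (within the scatter) and in place of 4-(dimethylamino)phenyl gives a number 0.07 log units higher from compound 2 to compound 4 (within the scatter) so compound 2, compound 3 and compound 4 cannot be told apart in this assay, despite their different ring substituents. Compound 1 remains separate from this cluster, with a number 1.09 log units lower from compound 1 to compound 4 (beyond the scatter) so among these compounds a halogen on the phenyl ring is not enough to reproduce the value of compound 1, and 2-fluorophenyl goes against any such reading. Nothing shown explains why 2,6-dichlorophenyl stands apart from the other three groups at this position.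

As far as these compounds go, it remains open whether 2-chlorophenyl or 2,6-difluorophenyl would fall with compound 1 or with the other three, and where a cyclohexyl ring or a phenyl bearing a carboxylic acid would fall at this position. The compounds shown also vary only this one position, so they leave open whether the separation of 2,6-dichlorophenyl would hold with any change elsewhere on the shared core.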